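The compounds below may be only part of what the source reports. "The series", "measured", "known", "first", "only" and "open" are said of these compounds alone.

Of the compounds shown here, two built on a shared core have so far been tested in a functional assay on MCF7 cells (Homo sapiens) for antiproliferative activity, read by MTT assay, with a stated time of 72 h; on this read-out higher numbers stand for weaker inhibition and lower numbers for stronger inhibition. Compound 1 `CCN1CCN(c2cc(C)c3cc(NC(=O)c4cccc(Cl)c4)ccc3n2)CC1` gives 3820 nM, the higher of the two numbers. Compound 2 `Cc1cc(N2CCN(C(C)C)CC2)nc2ccc(NC(=O)c3ccc(Cl)c(Cl)c3)cc12` gives 1710 nM, a lower number, and the gap between the two lies beyond the usual scatter of the measurement. Compound 3 `CCN1CCN(c2cc(C)c3cc(NC(=O)c4cccc(Br)c4)ccc3n2)CC1` differs from compound 1 in one place: bromo in place of chloro on an aromatic carbon. Among the measured compounds shown here, no measured pair shows the effect of such a swap, so the step of a 1.1-fold lower number from compound 1 to compound 3 (0.04 log units; within the scatter) is expected to be small, within the scatter, in no certain direction. Compound 3 is therefore estimated at 3500 nM, with a range from 1500 nM to 8000 nM.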

Compound 3, half-maximal inhibitory concentration: 11600 nM
For compound 3 the middle estimate is 3.3-fold (0.52 log units) below the measured one; measured number above the stated range.
By their numbers in this assay, from the lowest: compound 2; then compound 1; then compound 3.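

The 3-chlorophenyl group turns out to be sensitive to a swap of one halogen: in this assay, 3-bromophenyl in its place gives a 3.0-fold higher number from compound 1 to compound 3 (0.48 log units; beyond the scatter), which means weaker inhibition. The counts of hydrogen-bond donors, hydrogen-bond acceptors and net charge stay the same, so even this small change on the aromatic carbon matters, and chloro reads better than bromo here. No measurement at hand explains this step. From the compounds shown here alone, how fluoro, methoxy or plain hydrogen would read at this place remains open. So does the effect of an amine or a carboxylic acid there.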